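Extending a methoxy to a propargyloxy: an expected value

A few compounds are considered here, and "the series" means these few. Any claim that something is new, unique, unknown or untested is made for them only; others in the source may bear on it.

Compound 1 `COc1ccc(/C=C/C(=O)Nc2cc(C(=O)c3cc(OC)c(OC)c(OC)c3)cc(OC)c2OC)cc1OC`: 1300 nM
Compound 2 `COc1ccc(/C=C/C(=O)Nc2cc(C(=O)c3cc(OC)c(OC)c(OC)c3)cc(OC)c2OC)cc1`: 9400 nM
Compound 3 `COc1cccc(/C=C/C(=O)Nc2cc(C(=O)c3cc(OC)c(OC)c(OC)c3)cc(OC)c2OC)c1`: 6700 nM

In a functional assay on B16 cells (Mus musculus) for cytotoxicity, read by MTT assay, with a stated time of 72 h (on this read-out higher numbers stand for weaker inhibition and lower numbers for stronger inhibition), compound 3 gives the second highest of the three numbers. Its nearest neighbour is compound 2, and the gap a 1.4-fold lower number from compound 2 to compound 3 (0.15 log units; within the scatter) lies within the scatter, so no order can be set between these two. The furthest is compound 1; the step of a 5.2-fold higher number from compound 1 to compound 3 (0.71 log units; beyond the scatter) is beyond the scatter, as is the parallel step a 7.2-fold higher number from compound 1 to compound 2 (0.86 log units; beyond the scatter).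

Compound 4 `C#CCOc1cccc(/C=C/C(=O)Nc2cc(C(=O)c3cc(OC)c(OC)c(OC)c3)cc(OC)c2OC)c1` differs from compound 3 by ethynyl in place of hydrogen on a saturated chain carbon bound to an oxygen on an aromatic ring. Going by the values given here, none of the measured steps touches this change: the two steps from compound 1 remove a methoxy from an aromatic ring altogether, and the step from compound 2 to compound 3 moves a methoxy without altering it. The measured data therefore give no direction for growing the methyl of an existing methoxy into a propargyl.

With nothing to push the number either way, the expected step of a 1.1-fold lower number from compound 3 to compound 4 (0.05 log units; within the scatter) is none beyond the scatter. Among the compounds with values here, compound 4 is thus estimated at 6000 nM in this assay, within a range from 1800 nM to 20000 nM that is kept wide, since the change has no measured precedent here.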

Compound 4, half-maximal inhibitory concentration: 5100 nM
Beside the measured number, compound 4's estimate is 1.2-fold (0.07 log units) above it; the measured number falls inside the stated range.
By their numbers in this assay, from the lowest: compound 1; then compounds 4, 3 and 2 (each within the scatter of the next).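

In this assay, going by these compounds alone, growing the methyl of a methoxy into a propargyl is the first change here to alter a methoxy rather than remove or move it, and it gives a 1.3-fold lower number from compound 3 to compound 4 (0.12 log units; within the scatter) so the added ethynyl brings no readable shift at this position. The same holds against the other single-methoxy compound, with a 1.8-fold lower number from compound 2 to compound 4 (0.27 log units; within the scatter) while the comparison with the 3,4-dimethoxyphenyl compound shows a 3.9-fold higher number from compound 1 to compound 4 (0.59 log units; beyond the scatter) so the propargyloxy does not make up for the gap to compound 1, which keeps the lowest number of the four. Nothing in the data at hand explains why this added ethynyl leaves the number level.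

As far as these compounds go, it stays open whether the same extension would also leave the number level on the methoxy groups of compound 1 or compound 2, where the starting point differs. From the compounds shown here alone, it is equally open whether something other than the ethynyl at this spot, such as a longer saturated chain, a terminal amine or a carboxylic acid, would move the number beyond the scatter.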